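Carbonyl substituent series: phenyl ketone analogue

A few compounds are considered here, and "the series" means these few. Any claim that something is new, unique, unknown or untested is made for them only; others in the source may bear on it.

Measured so far, in a physicochemical assay for lipophilicity; a higher number here means a more lipophilic compound, a lower number a more polar compound:
compound 1 `CC(/C=C/CC(C)CCCC(C)C)=C\C(=O)O` gives 5.95
compound 2 `C#CCSC(=O)/C=C(C)/C=C/CC(C)CCCC(C)C` gives 5.07
compound 3 `CC(/C=C/CC(C)CCCC(C)C)=C\C(=O)CC(C)C` gives 7.22

Compound 3 sits at the top of this assay, with compound 1 nearest and compound 2 furthest. Both measured steps into compound 3 act at the carbonyl carbon: a number 1.27 log units higher from compound 1 to compound 3 (beyond the scatter) and a number 2.15 log units higher from compound 2 to compound 3 (beyond the scatter), while a number 0.88 log units lower from compound 1 to compound 2 (beyond the scatter). Compound 4 `CC(/C=C/CC(C)CCCC(C)C)=C\C(=O)c1ccccc1` changes the same position: phenyl in place of isobutyl on a carbonyl carbon. Unlike those steps, neither group here carries a heteroatom, so nothing measured in this series maps directly onto it; an exchange of two carbon-only groups of similar size is expected to move this assay little, if at all, perhaps a slight rise. For compound 4 the estimate is 7.4, range 6.9 to 7.9, a step expected as a number 0.18 log units higher from compound 3 to compound 4 (within the scatter).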

Compound 4, partition coefficient: 7.26
Estimate against measurement, compound 4: 0.14 log units above; the range from low to high includes it.
By their numbers in this assay, from the lowest: compound 2; then compound 1; then compounds 3 and 4 (each within the scatter of the next).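

In this assay, among these compounds, phenyl in place of isobutyl on a carbonyl carbon is the first exchange at this position that stays within the scatter (a number 0.04 log units higher from compound 3 to compound 4 (within the scatter)), so compound 3 and compound 4 are not separated. Phenyl keeps the large gaps to the hydroxy and propargylsulfanyl groups (a number 1.31 log units higher from compound 1 to compound 4 (beyond the scatter) and a number 2.19 log units higher from compound 2 to compound 4 (beyond the scatter)), as isobutyl did. Nothing available explains this result.

Still open, going by these compounds, is whether a longer chain or a cyclohexyl group on the carbonyl carbon would stay level with phenyl and isobutyl. Where an amine at this position would fall is also unresolved.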